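Thiazolyl amide as the next step in the series

This account rests on a few compounds, and the source may have more. Where it says the series, first, only, none or still open, it means among the compounds named here.

In a functional assay on A549 cells (Homo sapiens) for inhibition, read by MTT assay, with a stated time of 72 h (a higher number here means a weaker inhibitor, a lower number a stronger inhibitor), compound 1 (`O=C(Nc1cccc(Br)c1)C1CCN(C/C=C/c2ccccc2)CC1`) gives 16500 nM and compound 2 (`N#Cc1ccc(NC(=O)C2CCN(C/C=C/c3ccccc3)CC2)cc1`) gives 40200 nM, the higher of the two numbers. Compound 3 (`O=C(Nc1nccs1)C1CCN(C/C=C/c2ccccc2)CC1`) carries 1,3-thiazol-2-yl in place of 4-cyanophenyl on the amide-type nitrogen: 1,3-thiazol-2-yl in place of 4-cyanophenyl on an amide-type nitrogen. Among the measured compounds shown here, only one measured step bears on this position, a 2.4-fold higher number from compound 1 to compound 2 (0.39 log units; beyond the scatter), and it is modest. Neither measured compound has a five-membered aromatic ring here, so the direction rests on little. Compound 2 sits at the top of this small range at 40200 nM, so a move towards a lower number is expected, though not clearly beyond the scatter. The estimated step in this assay is a 1.7-fold lower number from compound 2 to compound 3 (0.22 log units; within the scatter). For compound 3 the expected value is 24000 nM, with an estimated range of 8000 nM to 70000 nM.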

Compound 3, half-maximal inhibitory concentration: 34900 nM
Beside the measured number, compound 3's estimate is 1.5-fold (0.16 log units) below it; measured number inside the range.
By their numbers in this assay, from the lowest: compound 1; then compounds 3 and 2 (each within the scatter of the next).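

In this assay, the change from 4-cyanophenyl to 1,3-thiazol-2-yl on the amide-type nitrogen leaves the reading within the scatter (a 1.2-fold lower number from compound 2 to compound 3 (0.06 log units; within the scatter)), so a five-membered aromatic ring with 2 hetero atoms and a six-membered aromatic ring of carbon only are not told apart here. Set against 3-bromophenyl, the same thiazolyl amide gives a step beyond the scatter (a 2.1-fold higher number from compound 1 to compound 3 (0.33 log units; beyond the scatter)), which leaves compound 1 as the strongest inhibitor of the three, with modest steps to both others. No measured evidence accounts for these numbers.

From the compounds shown here alone, whether the bromine or the phenyl ring carrying it sets compound 1 apart remains open. Also open, going by these compounds, is how an amine, a carboxylic acid or a longer chain on the amide-type nitrogen would read in this assay.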